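A few compounds are considered here, and "the series" means these few. Any claim that something is new, unique, unknown or untested is made for them only; others in the source may bear on it.

Three compounds have numbers in a functional assay on MGC-803 cells (Homo sapiens) for inhibition, read by CCK-8 assay, with a stated time of 48 h; a lower number here means a stronger inhibitor, a higher number a weaker inhibitor. Compound 1 `COc1ccc(CN(C(=O)CSc2nc3ccccc3o2)c2cc(OC)c(OC)c(OC)c2)cc1` gives 450 nM, and compound 2 `COc1ccc(CN(C(=O)CSC(=S)N2CCc3cc(OC)ccc32)c2cc(OC)c(OC)c(OC)c2)cc1` gives 11700 nM. Going by these compounds, compound 3 `COc1ccc(CN(C(=O)CSC(=S)N2CCN(C(=O)OC(C)(C)C)CC2)c2cc(OC)c(OC)c(OC)c2)cc1OC` gives > 20000 nM, which is a limit of the assay and not a number, so its exact standing is unknown. Compound 4 `COc1ccc(CN(C(=O)CSC(=S)N2CCN(C(=O)OC(C)(C)C)CC2)c2cc(OC)c(OC)c(OC)c2)cc1O` differs from compound 3 at one place, with hydrogen in place of methyl on an oxygen on an aromatic ring. For the measured compounds named here, no measured pair shows this methoxy to hydroxy change, so only a modest move towards stronger inhibition is expected, possibly none beyond the scatter. The expected change is an at least 1.6-fold lower number from compound 3 to compound 4 (0.22 log units; that floor lies within the scatter). For compound 4 the estimated value is 12000 nM, with an expected range of 3000 nM to 30000 nM.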

Compound 4, half-maximal inhibitory concentration: 82 nM
Estimate against measurement, compound 4: 150-fold (2.17 log units) above; measured number outside the range, below it.
By their numbers in this assay, from the lowest: compound 4; then compound 1; then compound 2. At a limit, above all of these: compound 3.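

In this assay, the change from 3,4-dimethoxybenzyl to 3-hydroxy-4-methoxybenzyl gives an at least 240-fold lower number from compound 3 to compound 4 (2.38 log units; beyond the scatter), the first sign that this one oxygen substituent can carry a large share of the activity in the series. For the compounds shown here, no earlier compound carried a hydroxy group. Compound 3 stands at a limit and not a number, so the step has only a floor: the limit of > 20000 nM in this assay, at which 1 of the 4 values shown sits.

Going by these compounds, whether an amine or a fluorine at this place would keep the gain remains open. So does whether the hydroxy group acts alike on the core of compound 1.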